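The compounds below may be only part of what the source reports. "The series", "measured", "known", "first", "only" and "open" are said of these compounds alone.

Compound 1 `CCCCCN1C(=O)C/C(=C\c2cccc(C(=O)NCCCC)c2)C1=O` in an ADME assay on HCT-116 cells (Homo sapiens) for cytotoxicity, read by MTT assay, with a stated time of 72 h (a higher number here means a weaker inhibitor, a lower number a stronger inhibitor), gives > 100000 nM, which is a limit of the assay and not a number.
Compound 2 `COc1ccc(NC(=O)c2cccc(/C=C3\CC(=O)N(c4ccccc4)C3=O)c2)c(C)c1` in this assay gives > 100000 nM, again a limit.
Compound 3 `O=C(Nc1ccc(Cl)cc1)c1cccc(/C=C2\CC(=O)N(Cc3ccccc3)C2=O)c1` in this assay gives > 100000 nM, again a limit.

Compound 2 stands where every measured compound stands: at the limit, with no number of its own, so nothing on these readings separates it from compound 1 or compound 3. That is the limit of > 100000 nM in this assay, at which 3 of the 3 values shown sit. Compound 4 `Cc1cccc(NC(=O)c2cccc(/C=C3\CC(=O)N(c4ccccc4)C3=O)c2)c1` has not yet been measured in this assay. It differs from compound 2 in one way: 3-methylphenyl in place of 4-methoxy-2-methylphenyl on an amide-type nitrogen. The amide-type nitrogen carries a 3-methylphenyl instead of a 4-methoxy-2-methylphenyl, and the rest of the shared core is unchanged. Within the data shown here, no step between measured compounds exists to show how large such a change can be here. Because every value sits at the limit of > 100000 nM in this assay, at which 3 of the 3 values shown sit, the expectation is that compound 4 will also return only a limit, and that a step that the limit leaves unreadable from compound 2 to compound 4 is no step beyond the scatter. Compound 4 is expected to give about 150000 nM, within 50000 nM to 500000 nM, most likely reported as a limit.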

Compound 4, half-maximal inhibitory concentration: > 100000 nM
Compound 4 ended at the assay's limit (the forecaster's own chance of this, stated with the estimate: 85%); the middle value is on the limit's open side.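

No step can be read from compound 2 to compound 4 in this assay, since each compound returns only a limit and not a number: the limit of > 100000 nM in this assay, at which 4 of the 4 values shown sit.

The compounds shown leave open whether any change on the shared core would yield a readable value in this assay, and how large such a step would be.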